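A few compounds are considered here, and "the series" means these few. Any claim that something is new, unique, unknown or untested is made for them only; others in the source may bear on it.

Compound 1 `Nc1ccnc2c1nc(-c1ccccc1)n2CCCO` sits in an assay on isolated protein for inhibition of high affinity 3',5'-cyclic-AMP phosphodiesterase 7A (Homo sapiens), read by cAMP accumulation, with a stated time of 20 min (on this read-out higher numbers stand for weaker inhibition and lower numbers for stronger inhibition), at a limit of the assay, giving > 200000 nM. Compound 2 `CCCCCn1c(-c2ccccc2)nc2c(N)ccnc21` differs from it in one place; in this assay compound 2 likewise reaches only a limit, > 200000 nM. The step that the two limits leave unreadable from compound 1 to compound 2 is therefore unreadable, as both values sit at the limit of > 200000 nM in this assay, at which 2 of the 2 values shown sit. Compound 2 thus stands at the limit, together with compound 1. Compound 3 `CCCCCn1c(-c2ccccc2)nc2c(NCc3ccccc3)ccnc21` differs from compound 2 by benzyl in place of hydrogen on a nitrogen on an aromatic ring. Among the measured compounds shown here, no measured step bears on this change, and the single recorded step has no readable size. The expected step of an at least 1.3-fold lower number from compound 2 to compound 3 (0.12 log units; that floor lies within the scatter) is none beyond the scatter. Compound 3 is estimated at 150000 nM, range 20000 nM to 300000 nM, most likely again reported as a limit.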

Compound 3, half-maximal inhibitory concentration: > 200000 nM
Compound 3: no number, only a limit; the forecaster's own chance of this, stated with the estimate: 65%; at least 1.3-fold (0.12 log units) between middle value and limit.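

In this assay compound 3 gives > 200000 nM, a limit and not a number. No step from compound 2 to compound 3 can be read: the limit of > 200000 nM in this assay, at which 3 of the 3 values shown sit.

The compounds shown leave open which change to the shared core would give a readable value.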